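The source may report more compounds than this note shows. Statements on the series, on what has been measured and on what is new or still open speak of the compounds shown alone.

Working notes on the series.

The shared core is that of compound 1 `CCOC(=O)c1cnc(C(F)(F)F)nc1NN1C(=O)C=C(C)C1=O`, which in a functional assay on Jurkat cells for inhibition of nuclear factor NF-kappa-B complex (Homo sapiens) (a higher number here means a weaker inhibitor, a lower number a stronger inhibitor), gives 1000 nM. Among the three measured compounds, compound 1 stands second highest: compound 3 `CCOC(=O)c1cnc(-c2ccc(C(F)(F)F)cc2)nc1NN1C(=O)C=C(C)C1=O` is nearest, with 400 nM in this assay, while compound 2 `CCOC(=O)c1cnc(-c2csc(C)n2)nc1NN1C(=O)C=C(C)C1=O` is furthest, with 8000 nM. The two measured steps away from compound 1 pull in opposite directions: an 8.0-fold higher number from compound 1 to compound 2 (0.90 log units; beyond the scatter), whereas a 2.5-fold lower number from compound 1 to compound 3 (0.40 log units; beyond the scatter).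

Compound 4 `CCOC(=O)c1cnc(-c2ccc(Cl)s2)nc1NN1C(=O)C=C(C)C1=O` is not yet measured. It differs from compound 1 at the carbon between two ring nitrogen atoms: 5-chlorothiophen-2-yl in place of trifluoromethyl on an aromatic carbon. The entering group shares features with both prior replacements, a five-membered aromatic ring with one hetero atom as in compound 2, and a halogen-bearing aromatic ring as in compound 3. The step from compound 1 to compound 2 and the step from compound 1 to compound 3 both bear on it, and they disagree in direction, so neither a clear rise nor a clear fall is expected beyond the scatter. The estimate for compound 4 in this assay is therefore set close to compound 1, giving a 1.5-fold higher number from compound 1 to compound 4 (0.18 log units; within the scatter), with a wide range. Expected value for compound 4: 1500 nM, spanning 400 nM to 6000 nM.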

Compound 4, half-maximal inhibitory concentration: 300 nM
Compound 4: the middle estimate sits 5.0-fold (0.70 log units) above what was measured; the whole stated range lies above it.
By their numbers in this assay, from the lowest: compounds 4 and 3 (each within the scatter of the next); then compound 1; then compound 2.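

The new result shows that a five-membered aromatic ring with one hetero atom can replace trifluoromethyl at the carbon between two ring nitrogen atoms without raising the number in this assay, with a 3.3-fold lower number from compound 1 to compound 4 (0.52 log units; beyond the scatter). Compound 2 therefore no longer stands for five-membered aromatic rings as a class: a 27-fold lower number from compound 2 to compound 4 (1.43 log units; beyond the scatter), so at this position the outcome depends on more than ring size, and the two rings differ in their hetero atoms, their substituent and their point of attachment. A six-membered aromatic ring is also not needed to reach the level of compound 3, since a 1.3-fold lower number from compound 3 to compound 4 (0.12 log units; within the scatter) lies within the scatter.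

Nothing at hand accounts for the wide gap between the thiazole and chlorothiophene compounds. Still open, from the compounds shown here alone, is whether the chlorine itself matters, which a thiophen-2-yl without chlorine or a 5-methylthiophen-2-yl at this carbon would test, and whether a non-aromatic group, such as a morpholine ring or a simple amine, is tolerated here.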